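Bromo for methyl: a paired step in the series

The source may hold more compounds than are shown below. What is called first, only, known or untested is meant among the compounds shown, and "the series" means these compounds.

Measured so far in an assay on isolated protein for inhibition of Alpha glucosidase (Homo sapiens), read by spectrophotometry, with stated times of 15 min and 30 min; a higher number here means a weaker inhibitor, a lower number a stronger inhibitor:
compound 1, `Cc1ccc(-c2cc(-c3ccc(Br)cc3)nc(SCc3ccc(Cl)cc3)n2)cc1`, gives 19000 nM
compound 2, `Cc1ccc(-c2cc(-c3cccc(Br)c3)nc(SCc3ccccc3Cl)n2)cc1`, gives 19000 nM
compound 3, `Clc1ccc(CSc2nc(-c3ccc(Br)cc3)cc(-c3ccc(Br)cc3)n2)cc1`, gives 19000 nM

Compound 1 and compound 3 share a core and differ by bromo in place of methyl on an aromatic carbon. The step is no change at the digits printed from compound 1 to compound 3 (within the scatter). Compound 2 is built from the same atoms as compound 1, joined differently; the difference between the two cores is not broken down here. In this assay compound 2 stands level with compound 1 and compound 3, within the scatter of either.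

Compound 4, `Clc1ccccc1CSc1nc(-c2ccc(Br)cc2)cc(-c2cccc(Br)c2)n1`, is not yet measured. It differs from compound 2 by bromo in place of methyl on an aromatic carbon, the same change that separates compound 1 from compound 3, made on the core of compound 2 instead. Since the earlier step left the value unchanged, the step from compound 2 to compound 4 in this assay is expected to be no change at the digits printed from compound 2 to compound 4 (within the scatter). This expectation rests on no change at the digits printed from compound 1 to compound 3 (within the scatter) and on the starting point of compound 2, which in this assay is 19000 nM. Compound 4 is therefore estimated at 19000 nM, with a likely range of 9000 nM to 40000 nM.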

Compound 4, half-maximal inhibitory concentration: 19000 nM
Beside the measured number, compound 4's estimate shows no gap at the digits printed; the measured number falls inside the stated range.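

Replacing 4-methylphenyl with 4-bromophenyl on the second core gives, in this assay, no change at the digits printed from compound 2 to compound 4 (within the scatter). Set beside the same replacement on the first core, the two steps do not differ: the same change on two cores in this assay, no change at the digits printed (within the scatter) from compound 1 to compound 3 and no change at the digits printed (within the scatter) from compound 2 to compound 4, 1.0-fold (0.00 log units) apart, within the scatter of two such steps. Within the data shown here, for these two cores, the change therefore carries from one to the other with the same null outcome, but this shows only that the replacement leaves the value unmoved in both cases; with no step of measurable size to compare, it does not show that a larger effect would transfer, or that the outcome would hold on any further core.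

The four compounds shown stand level and carry only methyl or bromo at this place on the aromatic ring, so they leave open whether any substituent there can move the value at all. How an amine or a carboxylic acid at the same aromatic carbon would read on either core remains an open question for the series.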